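Moving the Methyl Around the Pendant Phenyl Ring

The source may hold more compounds than are shown below. What is called first, only, known or untested is meant among the compounds shown, and "the series" means these compounds.

In a functional assay on A549 cells (Homo sapiens) for antiproliferative activity, read by CCK-8 assay, with a stated time of 72 h (on this read-out higher numbers stand for weaker inhibition and lower numbers for stronger inhibition), compound 1 `CC1=NN(c2ccccc2)C(=O)C12C=CC(=O)C=C2c1cccc(C)c1` gives 16500 nM, the lowest of the two numbers reported. Compound 2 `CC1=NN(c2ccc(Cl)cc2)C(=O)C12C=CC(=O)C=C2c1cccc(C)c1` gives 38400 nM in this assay, and the change was a 2.3-fold higher number from compound 1 to compound 2 (0.37 log units; beyond the scatter). Compound 3 `CC1=NN(c2ccc(Cl)cc2)C(=O)C12C=CC(=O)C=C2c1ccccc1` reaches only the assay limit, > 100000 nM, in this assay. The step of an at least 2.6-fold higher number from compound 2 to compound 3 (0.41 log units; beyond the scatter) shows that hydrogen in place of methyl on that aromatic carbon weakens inhibition at least modestly. Compound 4 `CC1=NN(c2ccccc2)C(=O)C12C=CC(=O)C=C2c1ccc(C)cc1` differs from compound 1 by 4-methylphenyl in place of 3-methylphenyl on a double-bonded ring carbon. Within the data shown here, no measured step moves the methyl rather than removing it, so the only guidance is that the methyl counts. The step is therefore expected to be a 1.2-fold higher number from compound 1 to compound 4 (0.08 log units; within the scatter), and compound 4 is estimated at 20000 nM, between 7000 nM and 60000 nM.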

Compound 4, half-maximal inhibitory concentration: 19300 nM
Beside the measured number, compound 4's estimate is 1.0-fold (0.02 log units) above it; measured number inside the range.
By their numbers in this assay, from the lowest: compounds 1, 4 and 2 (each within the scatter of the next, the first and the last beyond it). At a limit, above all of these: compound 3.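

In this assay the change to 4-methylphenyl in place of 3-methylphenyl on this double-bonded ring carbon gives a 1.2-fold higher number from compound 1 to compound 4 (0.07 log units; within the scatter) and so shows that these two placings of the methyl cannot be told apart on this read-out. Among these compounds, the earlier steps had only added a chloro or removed the methyl, so this is the first view of the methyl in a different place on the pendant phenyl ring. Nothing shown gives a reason for this result. Still open, as far as these compounds go, is how 2-methylphenyl would read here. Also open, from the compounds shown here alone, is whether an ethyl chain, a methoxy group or an amine could take the place of the methyl on that ring.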